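The source may hold more compounds than are shown below. What is called first, only, known or untested is meant among the compounds shown, and "the series" means these compounds.

The series shares the core of compound 1 `NS(=O)(=O)c1cc(-c2nnc(CN3CCN(c4ccccc4)CC3)o2)c(Cl)cc1SCc1ccccc1`. In a functional assay on MCF7 cells (Homo sapiens) for cytotoxicity, read by MTT assay, with a stated time of 72 h (a higher number here means a weaker inhibitor, a lower number a stronger inhibitor), compound 1 gives 295000 nM, the highest of the three numbers in hand. Compound 2 `NS(=O)(=O)c1cc(-c2nnc(CN3CCN(c4ccc(Cl)cc4)CC3)o2)c(Cl)cc1SCc1ccccc1` gives 280000 nM in this assay, and the step of a 1.1-fold lower number from compound 1 to compound 2 (0.02 log units; within the scatter). Compound 3 `[N-]=[N+]=NCc1nnc(-c2cc(S(N)(=O)=O)c(SCc3ccccc3)cc2Cl)o1` gives 55000 nM in this assay, and the step of a 5.4-fold lower number from compound 1 to compound 3 (0.73 log units; beyond the scatter).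

Compound 4 `NS(=O)(=O)c1cc(-c2nnc(CNS(=O)(=O)c3ccc(Cl)cc3)o2)c(Cl)cc1SCc1ccccc1` is not yet measured. It differs from compound 1 by ((4-chlorophenyl)sulfonyl)amino in place of 4-phenylpiperazin-1-yl on a saturated chain carbon bound to an aromatic carbon. Among the measured compounds shown here, of the measured steps, the one from compound 1 to compound 3 bears on this change most closely: it also removes the 4-phenylpiperazin-1-yl group from the same saturated chain carbon, and the number fell modestly. The step from compound 1 to compound 2 concerns only chloro in place of hydrogen on an aromatic carbon and stayed within the scatter. The group entering compound 4 is, however, not small like azido, so the change is not the same as that to compound 3. For the measured compounds named here, a step in the direction of a lower number, smaller than the one to compound 3, is therefore expected, with wide uncertainty. For compound 4 the expected step is a 2.3-fold lower number from compound 1 to compound 4 (0.36 log units; beyond the scatter). Compound 4 is estimated at 130000 nM in this assay, within a range from 45000 nM to 380000 nM.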

Compound 4, half-maximal inhibitory concentration: 30000 nM
Compound 4: middle estimate off by 4.3-fold (0.64 log units), on the high side; measured number outside the range, below it.
By their numbers in this assay, from the lowest: compounds 4 and 3 (each within the scatter of the next); then compounds 2 and 1 (each within the scatter of the next).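

In this assay, a 9.8-fold lower number from compound 1 to compound 4 (0.99 log units; beyond the scatter) shows that a lower number at this saturated chain carbon does not depend on a group as small as azido: ((4-chlorophenyl)sulfonyl)amino replaces 4-phenylpiperazin-1-yl, a group of nearly the same heavy-atom count, and the step is still beyond the scatter. With a 1.8-fold lower number from compound 3 to compound 4 (0.26 log units; within the scatter), azido and ((4-chlorophenyl)sulfonyl)amino are not separated in this assay, so among the four compounds the two that lack 4-phenylpiperazin-1-yl fall together, and compounds 1 and 2, which keep the piperazine ring, stay at the high end. No measurement in hand bears on why the number moves with this change, so the link between these groups and the cell read-out remains descriptive only.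

From the compounds shown here alone, it remains open whether the amide hydrogen of the entering group or its chloro substituent contributes, which a phenylsulfonylamino group without chlorine or an N-methyl sulfonamide at the same carbon would test. Going by these compounds, it is equally open how a simple primary amine, a carboxylic acid or a longer chain bearing the sulfonylamino group would read at this position.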